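Pentylamino for hydroxy on the core of compound 1

The source may hold more compounds than are shown below. What is called first, only, known or untested is meant among the compounds shown, and "the series" means these compounds.

Compound 1 `Nc1nc(O)nc2c1nc(O)n2Cc1ccccc1` gives the lowest number of the three measured in a functional assay (spleen, spleen) for activation, with Mus musculus as the target (a higher number here means that more compound is needed for the effect, a lower number that less compound is needed), at 0.1 uM. Among the compounds with values here, compound 2 `Cc1ccc(Cn2c(O)nc3c(N)ncnc32)cc1` gives 10 uM in this assay, and compound 3 `Nc1ncnc2c1nc(O)n2Cc1ccc(Cl)cc1` gives 10 uM; the one measured step, no change at the digits printed from compound 2 to compound 3 (within the scatter), concerns a different change and is no guide here. Compound 4 `CCCCCNc1nc(N)c2nc(O)n(Cc3ccccc3)c2n1` differs from compound 1 by pentylamino in place of hydroxy on an aromatic carbon. Within the data shown here, no measured pair shows this exchange, so the expectation rests on compound 1 alone, at 0.1 uM. The step of a 3.3-fold lower number from compound 1 to compound 4 (0.52 log units; beyond the scatter) is estimated as a modest gain, with a wide range since nothing measured tests it. Compound 4 is expected to give about 0.03 uM in this assay, between 0.003 uM and 0.3 uM.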

Compound 4, minimum effective concentration: 0.1 uM
For compound 4 the middle estimate is 3.3-fold (0.52 log units) below the measured one; the range from low to high includes it.
By their numbers in this assay, from the lowest: compounds 1 and 4 (each within the scatter of the next); then compounds 2 and 3 (each within the scatter of the next).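

In this assay pentylamino in place of hydroxy, on the aromatic carbon between two ring nitrogen atoms, shows no change at the digits printed from compound 1 to compound 4 (within the scatter). This position of the shared core therefore accepts a group of 6 heavy atoms where hydroxy has 1, which compounds 1 to 3 could not show. Nothing measured here accounts for this result.

Going by these compounds, whether a longer chain such as octylamino, or a carboxylic acid, would keep the number at this position remains open. So does whether a shorter chain such as ethylamino would.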